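The source may hold more compounds than are shown below. What is called first, only, known or untested is meant among the compounds shown, and "the series" means these compounds.

Going by the values given here, in a functional assay on A549 cells (Homo sapiens) for cytotoxicity, read by MTT assay, with a stated time of 72 h (a lower number here means a stronger inhibitor, a higher number a weaker inhibitor), compound 1 `O=C(N/N=C/c1cccc(Cl)c1Cl)Nc1cc2c(Nc3ccc(F)c(Cl)c3)ncnc2cc1O[C@H]1CCOC1` gives 25000 nM, while compound 2 `O=C(N/N=C/c1cc(Br)c(O)c(Br)c1)Nc1cc2c(Nc3ccc(F)c(Cl)c3)ncnc2cc1O[C@H]1CCOC1` gives 8910 nM, the lower of the two numbers so far. Compound 3 `CCN(CC)c1ccc(/C=N/NC(=O)Nc2cc3c(Nc4ccc(F)c(Cl)c4)ncnc3cc2O[C@H]2CCOC2)c(O)c1` keeps the shared core and differs from compound 2 only in the group on a carbon with a double bond to nitrogen: 4-(diethylamino)-2-hydroxyphenyl in place of 3,5-dibromo-4-hydroxyphenyl on a carbon with a double bond to nitrogen. Among the compounds with values here, one measured step bears on this change, since it falls at the same place: a 2.8-fold lower number from compound 1 to compound 2 (0.45 log units; beyond the scatter), which is modest but beyond the scatter. That single step shows how large a swap here can be, but it gives no reliable direction for this different group. No shift beyond the scatter is therefore expected in this assay, although a modest move either way remains possible. The expected step is a 1.1-fold higher number from compound 2 to compound 3 (0.05 log units; within the scatter). The estimated value for compound 3 is 10000 nM, with an expected range from 3000 nM to 30000 nM.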

Compound 3, half-maximal inhibitory concentration: 15700 nM
Compound 3: middle estimate off by 1.6-fold (0.20 log units), on the low side; measured number inside the range.
By their numbers in this assay, from the lowest: compounds 2, 3 and 1 (each within the scatter of the next, the first and the last beyond it).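

In this assay, placing 4-(diethylamino)-2-hydroxyphenyl on a carbon with a double bond to nitrogen gives a 1.8-fold higher number from compound 2 to compound 3 (0.25 log units; within the scatter) and a 1.6-fold lower number from compound 1 to compound 3 (0.20 log units; within the scatter), so this group, which carries no halogen, lies within the scatter of both earlier compounds. The gap between the two halogen-bearing compounds therefore no longer marks two separate levels, and a hydroxy group alone does not set the number here, since compound 3 has one and compound 1 does not, yet their values stay within the scatter of each other. No measurement is available to explain these numbers.

Going by these compounds, it remains open whether any group at this place can lower the number well beyond the scatter. An unsubstituted phenyl, a pyridine ring or a phenyl bearing a carboxylic acid could test how far this position can move the result.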